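The source may hold more compounds than are shown below. What is called first, only, known or untested is meant among the compounds shown, and "the series" means these compounds.

Measured in a functional assay on HepG2 cells (Homo sapiens) for cytotoxicity, read by sulforhodamine B assay, with a stated time of 24 h; a lower number here means a stronger inhibitor, a higher number a weaker inhibitor:
compound 1 `O=C1Nc2ccc(S(=O)(=O)N3CCOCC3)cc2/C1=N/c1ccc(O)cc1`: 10400 nM
compound 2 `N/N=C1\C(=O)Nc2ccc(S(=O)(=O)N3CCOCC3)cc21`: 32400 nM
compound 3 `O=C1Nc2ccc(S(=O)(=O)N3CCOCC3)cc2/C1=N/c1ccc(/N=C2\C(=O)Nc3ccc(S(=O)(=O)N4CCOCC4)cc32)cc1`: 8840 nM

Compound 1 stands within the scatter of compound 3, with compound 2 the highest number of the three. Compound 4 `CC(=O)c1cccc(/N=C2\C(=O)Nc3ccc(S(=O)(=O)N4CCOCC4)cc32)c1` is unmeasured and differs from compound 1 as follows: 3-acetylphenyl in place of 4-hydroxyphenyl on a double-bonded nitrogen. This puts 3-acetylphenyl in place of 4-hydroxyphenyl on a double-bonded nitrogen. Among the compounds with values here, the only measured step at this place is a 3.1-fold higher number from compound 1 to compound 2 (0.49 log units; beyond the scatter), and it swaps in amino, leaving no aromatic ring there, so it bears only loosely. Compound 4 keeps an aromatic ring at this place, as does compound 3 at 8840 nM, so no step beyond the scatter is expected in this assay. The expected step is a 1.1-fold lower number from compound 1 to compound 4 (0.04 log units; within the scatter). For compound 4 the estimated value is 9500 nM, with an expected range of 4000 nM to 22000 nM.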

Compound 4, half-maximal inhibitory concentration: 28600 nM
Beside the measured number, compound 4's estimate is 3.0-fold (0.48 log units) below it; measured number above the stated range.
By their numbers in this assay, from the lowest: compounds 3 and 1 (each within the scatter of the next); then compounds 4 and 2 (each within the scatter of the next).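

In this assay, an aromatic ring on the double-bonded nitrogen does not by itself hold the level of compound 1: 3-acetylphenyl in place of 4-hydroxyphenyl gives a 2.8-fold higher number from compound 1 to compound 4 (0.44 log units; beyond the scatter) at this place. Amino and 3-acetylphenyl cannot be told apart here, with a 1.1-fold lower number from compound 2 to compound 4 (0.05 log units; within the scatter) in this series, so the presence of a ring does not separate them. Nothing at hand bears on the cause of either step.

Going by these compounds, whether the first step follows the loss of the hydroxyl or the arrival of the acetyl stays open. A plain phenyl or a methoxyphenyl at this place would help to part the two.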